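One Ring Substituent Changed, Inhibition Re-estimated

A few compounds are considered here, and "the series" means these few. Any claim that something is new, unique, unknown or untested is made for them only; others in the source may bear on it.

Compound 1 `COc1ccc(/C=C/C(=O)c2cccc(-n3cc(-c4ccccc4)nn3)c2)cc1O` was tested in a functional assay on RAW264.7 cells (Mus musculus) for inhibition, with a stated time of 4 days (a higher number here means a weaker inhibitor, a lower number a stronger inhibitor), where compound 1 gives 1510 nM. Compound 2 `COc1ccc(/C=C/C(=O)c2cccc(-n3cc(-c4ccccc4C(F)(F)F)nn3)c2)cc1O` differs only by a trifluoromethyl in place of hydrogen on an aromatic carbon; in this assay compound 2 gives 9120 nM. Among the measured compounds shown here, that single change produced a 6.0-fold higher number from compound 1 to compound 2 (0.78 log units; beyond the scatter), leaving compound 2 with the higher of the two numbers measured so far, that is, the weaker inhibitor of the pair. Compound 3 `COc1ccc(/C=C/C(=O)c2cccc(-n3cc(-c4ccc(Br)cc4)nn3)c2)cc1O` is the next step: 4-bromophenyl in place of 2-(trifluoromethyl)phenyl on an aromatic carbon. For the measured compounds named here, the only measured step that bears on it is the one from compound 1 to compound 2, a modest loss. Here the trifluoromethyl is removed again, while bromine appears on the entering ring, and no measured step shows what bromine alone does. The trifluoromethyl that now leaves accompanied a 6.0-fold higher number from compound 1 to compound 2 (0.78 log units; beyond the scatter), so compound 3 is expected to shift by a 3.6-fold lower number from compound 2 to compound 3 (0.56 log units; beyond the scatter). The estimate for compound 3 is 2500 nM, with a range from 1000 nM to 6500 nM.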

Compound 3, half-maximal inhibitory concentration: 6570 nM
Compound 3: the middle estimate sits 2.6-fold (0.42 log units) below what was measured; the whole stated range lies below it.
By their numbers in this assay, from the lowest: compound 1; then compounds 3 and 2 (each within the scatter of the next).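

In this assay, exchanging 2-(trifluoromethyl)phenyl for 4-bromophenyl gives a 1.4-fold lower number from compound 2 to compound 3 (0.14 log units; within the scatter), so the two substituted rings cannot be told apart here, even though the exchange alters both the group and where it sits on the ring. Measured against the unsubstituted phenyl, bromo in place of hydrogen gives a 4.4-fold higher number from compound 1 to compound 3 (0.64 log units; beyond the scatter), so a second, different substituent also goes with a weaker inhibitor, and compound 1 remains the strongest of the three. Nothing available explains why either substituent carries this loss.

Still open, as far as these compounds go, is what trifluoromethyl and bromo would each do if their places on the ring were swapped, since the group and its location change together here. Also open, from the compounds shown here alone, is whether an amine or a carboxylic acid on this ring would match compound 1 or improve on it.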